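The source may hold more compounds than are shown below. What is called first, only, known or untested is meant among the compounds shown, and "the series" means these compounds.

Compound 1 `CN(C)CCCCCn1c2c(c3ccccc31)C(=O)c1c[n+]([O-])c3ccccc3c1C2=O`: 240 nM
Compound 2 `O=C1c2c[n+]([O-])c3ccccc3c2C(=O)c2c1c1ccccc1n2Cc1cn([C@H]2C[C@H](O)[C@@H](CO)O2)nn1`: 280 nM

In a toxicity assay on L02 cells (Homo sapiens) for cytotoxicity, read by MTT assay, with a stated time of 72 h (a higher number here means a weaker inhibitor, a lower number a stronger inhibitor), compound 2 gives 280 nM and compound 1 gives 240 nM. These two numbers lie within the usual scatter of each other, so neither compound counts as the stronger inhibitor.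

Compound 3 `O=C1c2c[n+]([O-])c3ccccc3c2C(=O)c2c1c1ccccc1n2Cc1cn(C[C@@H](O)CO)nn1` has 2,3-dihydroxypropyl in place of 4-hydroxy-5-(hydroxymethyl)oxolan-2-yl on an aromatic nitrogen. Among the measured compounds shown here, no measured pair shows this change directly. Even so, compound 1 at 240 nM and compound 2 at 280 nM carry different groups on the shared core, so no step beyond the scatter is expected, in either direction. The expected step is a 1.1-fold lower number from compound 2 to compound 3 (0.05 log units; within the scatter).

For compound 3 the estimated value is 250 nM, with an expected range from 110 nM to 600 nM.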

Compound 3, half-maximal inhibitory concentration: 490 nM
Beside the measured number, compound 3's estimate is 2.0-fold (0.29 log units) below it, and the stated range covers the measured number.
By their numbers in this assay, from the lowest: compounds 1, 2 and 3 (each within the scatter of the next, the first and the last beyond it).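

In this assay, 2,3-dihydroxypropyl, which has no ring, in place of 4-hydroxy-5-(hydroxymethyl)oxolan-2-yl on the aromatic nitrogen gives a 1.8-fold higher number from compound 2 to compound 3 (0.24 log units; within the scatter) so this position tolerates the loss of that ring within the scatter. The larger swap, 1-(2,3-dihydroxypropyl)-1H-1,2,3-triazol-4-yl in place of 4-(dimethylamino)butyl, gives a 2.0-fold higher number from compound 1 to compound 3 (0.31 log units; beyond the scatter) and is only a modest step. Nothing at hand gives a reason for either step. Going by these compounds, whether a carboxylic acid or a plain methyl on that same aromatic nitrogen would move the number remains open.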